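The source may hold more compounds than are shown below. What is called first, only, known or untested is meant among the compounds shown, and "the series" means these compounds.

Measured so far:
- compound 1 `CO[C@@H]1[C@H]2OC(=O)C[C@H]2O[C@@H]1[C@@H](O)c1ccccc1`: 8450 nM
- compound 2 `O=C1C[C@H]2O[C@H](C(O)O)[C@H](O)[C@H]2O1`: 28 nM

In a functional assay on K562 cells (Homo sapiens) for inhibition, read by MTT assay, with a stated time of 72 h (on this read-out higher numbers stand for weaker inhibition and lower numbers for stronger inhibition), compound 1 gives 8450 nM as the higher of the two numbers, and the gap to compound 2 lies well beyond the scatter. The two compounds differ in more than one place, so that gap says nothing about any single change.

The next compound to be read is compound 3 `CO[C@@H]1[C@H]2OC(=O)C[C@H]2O[C@@H]1[C@H](O)c1ccccc1` and the comparison is with compound 1: the two compounds have the same atoms and bonds and differ only in configuration as drawn: 1 of 5 stereo elements differ; a stereocentre at a saturated chain carbon is drawn S in compound 1 and R in compound 3. Atoms and bonds stay the same, so only the configuration at that saturated chain carbon is tested. For the measured compounds named here, no measured pair isolates such an inversion, and its effect in this assay is not known from the data.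

Compound 2 at 28 nM shows that far lower numbers occur in this series, which leaves the downward direction open from compound 1. A moderate move toward stronger inhibition is therefore expected, with no change beyond the scatter also plausible. The expected size is a 2.1-fold lower number from compound 1 to compound 3 (0.32 log units; beyond the scatter) in this estimate. For compound 3 the estimated value is 4000 nM with an expected range from 800 nM to 15000 nM in this read-out.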

Compound 3, half-maximal inhibitory concentration: 5360 nM
Estimate against measurement, compound 3: 1.3-fold (0.13 log units) below; the measured number falls inside the stated range.
By their numbers in this assay, from the lowest: compound 2; then compounds 3 and 1 (each within the scatter of the next).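

In this assay, inverting the stereocentre at the saturated chain carbon gives a 1.6-fold lower number from compound 1 to compound 3 (0.20 log units; within the scatter), so this read-out does not separate the S and R configurations drawn at this carbon, at least with the phenyl group and the rest of the core of compound 1 unchanged. For the compounds shown here, until now the series offered no step that could be read for a single change, and this is the first information specific to this position: configuration at the chain carbon, taken alone, produces no shift beyond the scatter. The reading can be assigned to that one stereocentre, and to no other part of the structure, because the comparison is a clean one: the fact that compounds 1 and 3 differ only in the configuration as drawn

From the compounds shown here alone, whether configuration at this carbon stays without effect when the phenyl group gives way to another substituent, such as a pyridine ring or a longer chain, remains open. The compounds shown also leave open what an amine in place of the hydroxyl group on that carbon would give in this assay.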